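The source may hold more compounds than are shown below. What is called first, only, known or untested is meant among the compounds shown, and "the series" means these compounds.

Measured so far in a functional assay on SW480 cells (Homo sapiens) for cytotoxicity, read by MTT assay, with a stated time of 24 h; on this read-out lower numbers stand for stronger inhibition and higher numbers for weaker inhibition:

compound 1, `C=CC1=C(C(=O)NCc2ccc(Cl)cc2)C(c2ccc(OC)cc2)OC1`: > 100000 nM, a limit of the assay rather than a number.
compound 2, `C=CC1=C(C(=O)NCCC)C(c2ccc(Cl)c(Cl)c2)OC1`: > 100000 nM, likewise a limit.
compound 3, `C=CC1=C(C(=O)NC2CCCCC2)C(c2ccc(F)cc2)OC1`: > 100000 nM, likewise a limit.

The three compounds share one core and differ in the group on the amide nitrogen and in the substitution of the aryl ring. None of them gives a number in this assay; each value sits at the limit of > 100000 nM in this assay, at which 3 of the 3 values shown sit. Among the compounds with values here, compound 2 therefore stands where the other two stand, at the limit, and no step between measured compounds can be read from these data, so there is nothing yet to say about which changes move the read-out.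

Compound 4, `C=CC1=C(C(=O)NCCCCC)C(c2ccc(Cl)c(Cl)c2)OC1`, differs from compound 2 by ethyl in place of hydrogen on a saturated chain carbon, three bonds along the chain from an amide-type nitrogen. The amide substituent grows by two chain carbons while the aryl part stays as in compound 2. Within the data shown here, no measured pair shows what a change of this kind does in this assay. The expected step that the limit leaves unreadable from compound 2 to compound 4 is none beyond the usual scatter, because compound 2 sits at the limit of > 100000 nM in this assay, at which 3 of the 3 values shown sit, and a shift from there would have to be large to register as a number at all. Compound 4 is expected to give about 150000 nM, within 50000 nM to 500000 nM, and most probably to be reported again only as a limit.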

Compound 4, half-maximal inhibitory concentration: 27500 nM
Estimate against measurement, compound 4: 5.5-fold (0.74 log units) above; measured number outside the range, below it.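

With ethyl in place of hydrogen on a saturated chain carbon, three bonds along the chain from an amide-type nitrogen, compound 4 is the only compound shown that gives a number in this assay. This position on the amide substituent is therefore one where the read-out responds: the aryl part stays as in compound 2, and the change from propyl to pentyl gives an at least 3.6-fold lower number from compound 2 to compound 4 (0.56 log units; beyond the scatter). That size is a floor rather than a full measure, because the starting point is a limit and not a number: the limit of > 100000 nM in this assay, at which 3 of the 4 values shown sit.

From the compounds shown here alone, whether the number keeps falling with a longer chain such as heptyl, or holds with an amine or a carboxylic acid at the end of the pentyl chain, remains open, as does whether the pentyl chain has the same effect on the aryl rings of compound 1 and compound 3. Steps from compound 1 or compound 3 to compound 4 cannot be read, as each pair differs in more than one place.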